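Alkyl chain extension in a rice whole-organism series

The source may report more compounds than this note shows. Statements on the series, on what has been measured and on what is new or still open speak of the compounds shown alone.

Measured in an ADME assay on the whole organism with Oryza sativa as the target, tested at 0.1 uM; on this read-out lower numbers stand for a stronger effect and higher numbers for a weaker effect at the one concentration tested:
compound 1, `CC(C)c1ccc(NC(=O)N[C@@H](C)c2ccccc2)cc1`, gives 98%
compound 2, `C[C@H](NC(=O)Nc1ccc(C(C)(C)C)cc1)c1ccccc1`, gives 100%
compound 3, `CCCCCCc1ccc(NC(=O)N[C@H](C)c2ccccc2)cc1`, gives 100%

The change methyl in place of hydrogen on a saturated chain carbon bound to an aromatic carbon and two saturated chain carbons moves the read-out by a number 2 percentage points higher from compound 1 to compound 2 (within the scatter). Compound 3 and compound 2 sit level at the digits reported, and the difference between the core of compound 3 and that of compound 1 is not broken down here.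

Compound 4, `CCCCCCCc1ccc(NC(=O)N[C@H](C)c2ccccc2)cc1`, is not yet measured. It differs from compound 3 by methyl in place of hydrogen on a saturated chain carbon, six bonds along the chain from an aromatic carbon, the same kind of change as from compound 1 to compound 2, but here the place is six bonds along the chain from an aromatic carbon rather than bound to an aromatic carbon and two saturated chain carbons. Because compound 3 gives 100% and the earlier step was a number 2 percentage points higher from compound 1 to compound 2 (within the scatter), the expected step is a number 1 percentage points lower from compound 3 to compound 4 (within the scatter). Compound 4 is estimated at 99%, expected between 91% and 100%.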

Compound 4, a percentage reported as activity, at one concentration (the size of the read-out at that concentration, not a potency): 100%
The estimate for compound 4 lay 1 percentage points below the measured number; the measured number falls inside the stated range.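

In this assay, methyl in place of hydrogen on a saturated chain carbon, six bonds along the chain from an aromatic carbon, reads as no change at the digits printed from compound 3 to compound 4 (within the scatter). Set beside the earlier step, the same change on the two cores gives steps that cannot be told apart: the same change on two cores in this assay, a number 2 percentage points higher (within the scatter) from compound 1 to compound 2 and no change at the digits printed (within the scatter) from compound 3 to compound 4, 2 percentage points apart, within the scatter of two such steps. This shows agreement only among steps inside the scatter, at different places on different cores, so it does not show that the change moves the read-out on either core, nor that a step of real size would carry from one core to another.

Still open, from the compounds shown here alone, is whether any group moves the read-out. A chain longer than that of compound 4, or one ending in an amine or a carboxylic acid, would test this.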